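Trimming One Methyl from a Side Chain

The source may hold more compounds than are shown below. What is called first, only, known or untested is meant among the compounds shown, and "the series" means these compounds.

Measured in a functional assay on MDA-MB-435S cells (Homo sapiens) for cytotoxicity, read by MTT assay; a higher number here means a weaker inhibitor, a lower number a stronger inhibitor:
Compound 1 `COc1ccc(-c2oc3c(CC=C(C)C)c(OC(C)C(=O)O)cc(O)c3c(=O)c2O)cc1`: 5700 nM
Compound 2 `COc1ccc(-c2oc3c(CC=C(C)C)c(OCCOC(=O)CCCC(=O)O)cc(O)c3c(=O)c2OCCOC(=O)CCCC(=O)O)cc1`: 6300 nM

Only these two values are known so far, and they lie within the usual scatter of repeated measurements. Compound 1 therefore stands level with compound 2, and neither can be ranked above the other.

The unmeasured compound 3 `COc1ccc(-c2oc3c(CC=C(C)C)c(OCC(=O)O)cc(O)c3c(=O)c2O)cc1` differs from compound 1 in one place: hydrogen in place of methyl on a saturated chain carbon bound to a carbonyl carbon and an oxygen on an aromatic ring. In words, this is hydrogen in place of methyl on a saturated chain carbon bound to a carbonyl carbon and an oxygen on an aromatic ring, which turns 1-carboxyethoxy into carboxymethoxy.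

Within the data shown here, no pair of measured compounds shows what such a change does, so the forecast rests on a single neighbour, compound 1 at 5700 nM. With so small an edit, no step beyond the scatter is expected in this assay, in either direction. The estimated change is a 1.1-fold higher number from compound 1 to compound 3 (0.02 log units; within the scatter). For compound 3 the expected value is 6000 nM, with an estimated range of 2500 nM to 14000 nM.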

Compound 3, half-maximal inhibitory concentration: 13500 nM
Estimate against measurement, compound 3: 2.3-fold (0.35 log units) below; the measured number falls inside the stated range.
By their numbers in this assay, from the lowest: compounds 1 and 2 (each within the scatter of the next); then compound 3.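

In this assay, taking the methyl off the saturated chain carbon bound to a carbonyl carbon and an oxygen on an aromatic ring gives a 2.4-fold higher number from compound 1 to compound 3 (0.37 log units; beyond the scatter) and so turns out not to be a silent edit: the step is modest, but this one carbon can shift the read-out on its own. Compound 1 and compound 2 differ in more than one place, so they could not tie any change in the number to a single group, whereas this pair isolates one small difference and shows that, of these two side chains, 1-carboxyethoxy goes with the lower number and carboxymethoxy with the higher. Nothing measured here accounts for why removing this methyl shifts the number, so the step stands as an observation without an explanation.

From the compounds shown here alone, it remains open whether a longer chain on this same carbon, such as an ethyl group, would lower the number further or raise it again. Going by these compounds, it is equally open whether the step would hold if an amide replaced the carboxylic acid on this side chain.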